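Series notes: ring substituent exchange, compound 2 to compound 3

The source may hold more compounds than are shown below. What is called first, only, known or untested is meant among the compounds shown, and "the series" means these compounds.

Within the data shown here, compound 2 `O=C(CCCCCc1cccc(O)c1)N1CCOC1=O` gives 8640 nM in an assay on HEK293 cells for inhibition of N-acylethanolamine-hydrolyzing acid amidase (Rattus norvegicus), read by LC-MS, with a stated time of 30 min (a lower number here means a stronger inhibitor, a higher number a weaker inhibitor), the higher of the two numbers so far; compound 1 `O=C(CCCCCc1cccc(I)c1)N1CCOC1=O` gives 3120 nM in this assay. Among the measured compounds shown here, the only single-change step measured is a 2.8-fold higher number from compound 1 to compound 2 (0.44 log units; beyond the scatter). Compound 3 `O=C(CCCCCc1cccc(CO)c1)N1CCOC1=O` differs from compound 2 by hydroxymethyl in place of hydroxy on an aromatic carbon. For the measured compounds named here, no measured step covers this exchange; the step from compound 1 to compound 2 at the same place was modest, so only a modest shift, within or just beyond the scatter, is expected here, direction uncertain. Compound 3 is expected at 6000 nM, between 2500 nM and 15000 nM. The expected step is a 1.4-fold lower number from compound 2 to compound 3 (0.16 log units; within the scatter).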

Compound 3, half-maximal inhibitory concentration: > 20000 nM
Compound 3: no number, only a limit; the forecaster's own chance of this, stated with the estimate: 5%; middle value at least 3.3-fold (0.52 log units) from the limit.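

Compound 3 gives no number in this assay, only a limit: the limit of > 20000 nM in this assay, at which 1 of the 3 values shown sits. Hydroxymethyl in place of hydroxy gives an at least 2.3-fold higher number from compound 2 to compound 3 (0.36 log units; beyond the scatter), and hydroxymethyl in place of iodo gives an at least 6.4-fold higher number from compound 1 to compound 3 (0.80 log units; beyond the scatter). This place on the aromatic ring, meta to a large group, therefore responds to a single added carbon, although hydroxy and hydroxymethyl have the same hydrogen-bond donor and acceptor counts.

On these data alone, the full size of both steps stays open with a limit alone. Also open, as far as these compounds go, is how an amine, a carboxylic acid or a longer hydroxyalkyl chain at this place would compare with compound 1.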